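Notes on the anilide side chain, compounds 2 and 3

A few compounds are considered here, and "the series" means these few. Any claim that something is new, unique, unknown or untested is made for them only; others in the source may bear on it.

Within the data shown here, in a functional assay on MCF7 cells (Homo sapiens) for cytotoxicity, read by MTT assay, with a stated time of 24 h, tested at 6.4 ug/mL (on this read-out higher numbers stand for a stronger effect at the one concentration tested and lower numbers for a weaker effect), compound 2 `Cn1cnnc1SCC(=O)Nc1ccc(-c2nc(-c3ccccc3)c(-c3ccccc3)n2C)cc1` gives 59.2%, the highest of the two numbers known so far. Among the measured compounds shown here, its nearest neighbour is compound 1 `Cn1c(-c2ccc(NC(=O)CSc3nc4ccccc4o3)cc2)nc(-c2ccccc2)c1-c1ccccc1`, which in this assay gives 42.3%; the one step between them, a number 16.9 percentage points higher from compound 1 to compound 2 (beyond the scatter), came from 4-methyl-4H-1,2,4-triazol-3-yl in place of 1,3-benzoxazol-2-yl on a sulfur. Compound 3 `CN(C)/C=C/N1CCN(CC(=O)Nc2ccc(-c3nc(-c4ccccc4)c(-c4ccccc4)n3C)cc2)CC1` is not yet measured. The change it carries is 4-(2-(dimethylamino)ethenyl)piperazin-1-yl in place of (4-methyl-4H-1,2,4-triazol-3-yl)sulfanyl on a saturated chain carbon bound to a carbonyl carbon. For the measured compounds named here, no measured step covers this exchange: the only known step kept the sulfur and swapped one sulfur-bound ring for another, whereas here the (4-methyl-4H-1,2,4-triazol-3-yl)sulfanyl group leaves altogether and 4-(2-(dimethylamino)ethenyl)piperazin-1-yl enters on the saturated chain carbon bound to the carbonyl carbon. Going by the values given here, the single step, modest in size, gives little basis for predicting a large move in either direction, so the expected step is a number 9.2 percentage points lower from compound 2 to compound 3 (within the scatter), within or near the scatter and with wide uncertainty. For compound 3 in this assay the estimate is 50%, expected to fall between 30% and 70%.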

Compound 3, a percentage reported as activity, at one concentration (the size of the read-out at that concentration, not a potency): 11.1%
Compound 3: middle estimate off by 38.9 percentage points, on the high side, and the stated range ends above it.
By their numbers in this assay, from the lowest: compound 3; then compound 1; then compound 2.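

Working notes on the position: in this assay the saturated chain carbon bound to a carbonyl carbon proves far more sensitive than the one earlier ring swap on the sulfur suggested, since 4-(2-(dimethylamino)ethenyl)piperazin-1-yl in place of (4-methyl-4H-1,2,4-triazol-3-yl)sulfanyl gives a number 48.1 percentage points lower from compound 2 to compound 3 (beyond the scatter) and counts as a large step. The same entering group in place of (1,3-benzoxazol-2-yl)sulfanyl gives a number 31.2 percentage points lower from compound 1 to compound 3 (beyond the scatter) and is also large, so the fall appears against both sulfur-linked compounds shown, whereas the earlier change, with the sulfur kept, was the modest a number 16.9 percentage points higher from compound 1 to compound 2 (beyond the scatter) in the opposite sense for the triazole. No measurement at hand speaks to why the number falls with this exchange.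

The compounds shown leave open which part of the entering group goes with the low number: a plain piperazin-1-yl, a 4-methylpiperazin-1-yl or a morpholin-4-yl on the same chain carbon would separate the ring from the 2-(dimethylamino)ethenyl group. Also open, on these data alone, is what the sulfur contributes, a question that a (4-methyl-4H-1,2,4-triazol-3-yl)oxy group in its place would address.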